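Chain length and amine size on the shared core

This account rests on a few compounds, and the source may have more. Where it says the series, first, only, none or still open, it means among the compounds named here.

Compound 1 `CN(C)CCCNc1nc(-c2ccc(NC(=O)Nc3ccccc3F)cc2)nc2ccsc12`: 470 nM
Compound 2 `CN(C)CCNc1nc(-c2ccc(NC(=O)Nc3ccccc3F)cc2)nc2ccsc12`: 510 nM
Compound 3 `CCN(CC)CCCNc1nc(-c2ccc(NC(=O)Nc3ccccc3F)cc2)nc2ccsc12`: 550 nM

All three numbers come from a functional assay on HT-29 cells (Homo sapiens) for cytotoxicity, read by MTT assay, with a stated time of 72 h; a lower number here means a stronger inhibitor, a higher number a weaker inhibitor. Compound 3 sits within the scatter of both others: a 1.2-fold higher number from compound 1 to compound 3 (0.07 log units; within the scatter) and a 1.1-fold higher number from compound 2 to compound 3 (0.03 log units; within the scatter). The unmeasured compound 4 `CCN(CC)CCNc1nc(-c2ccc(NC(=O)Nc3ccccc3F)cc2)nc2ccsc12` differs from compound 3 by diethylamino in place of (diethylamino)methyl on a saturated chain carbon, two bonds along the chain from a nitrogen on an aromatic ring. Among the measured compounds shown here, the one measured step of the same kind, a chain shortened by one carbon with the dimethyl amine in place, gave a 1.1-fold higher number from compound 1 to compound 2 (0.04 log units; within the scatter). The amine-size steps, a 1.2-fold higher number from compound 1 to compound 3 (0.07 log units; within the scatter) and a 1.1-fold higher number from compound 2 to compound 3 (0.03 log units; within the scatter), were also flat. In this assay no step beyond the scatter is therefore expected for compound 4. Compound 4 is estimated at 580 nM, between 300 nM and 1100 nM. The expected step is a 1.1-fold higher number from compound 3 to compound 4 (0.02 log units; within the scatter).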

Compound 4, half-maximal inhibitory concentration: 610 nM
Compound 4: the middle estimate sits 1.1-fold (0.02 log units) below what was measured; measured number inside the range.
By their numbers in this assay, from the lowest: compounds 1, 2, 3 and 4 (each within the scatter of the next).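

In this assay, the 2-(diethylamino)ethyl chain in place of 3-(diethylamino)propyl gives a 1.1-fold higher number from compound 3 to compound 4 (0.04 log units; within the scatter), so the chain-length step is now flat with both amines. Diethylamino in place of dimethylamino on the shorter chain gives a 1.2-fold higher number from compound 2 to compound 4 (0.08 log units; within the scatter), and the two changes together give a 1.3-fold higher number from compound 1 to compound 4 (0.11 log units; within the scatter). The amine change now reads the same at both chain lengths: the same change on two cores in this assay, a 1.2-fold higher number (0.07 log units; within the scatter) from compound 1 to compound 3 and a 1.2-fold higher number (0.08 log units; within the scatter) from compound 2 to compound 4, 1.0-fold (0.01 log units) apart, within the scatter of two such steps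

Still open, from the compounds shown here alone, is whether a ring amine such as morpholine or piperidine, or a longer chain carrying the diethylamino group, would take the number beyond the scatter.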